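This account rests on a few compounds, and the source may have more. Where it says the series, first, only, none or still open, it means among the compounds named here.

Working notes on the series, read in a functional assay on U-251 cells (Homo sapiens) for antiproliferative activity, read by MTT assay, with a stated time of 48 h; a higher number here means a weaker inhibitor, a lower number a stronger inhibitor. Compound 1 `COc1cc(-c2cccc3nc(-c4ccc(F)cc4)oc23)cc(OC)c1OC` gives > 25000 nM, which is a limit of the assay and not a number. Compound 3 `COc1cc(-c2cccc3nc(-c4cccc(C)c4)oc23)cc(OC)c1OC` gives > 25000 nM, again only a limit. Within the data shown here, compound 2 `COc1cc(-c2cccc3nc(-c4cccc(Cl)c4)oc23)cc(OC)c1OC` gives 18500 nM, the one actual number so far. Compound 3 thus stands at the limit of > 25000 nM in this assay, at which 2 of the 3 values shown sit, with no measured value of its own.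

The move to compound 4 `COc1cc(-c2cccc3nc(-c4ccc5cc[nH]c5c4)oc23)cc(OC)c1OC` is 1H-indol-6-yl in place of 3-methylphenyl on an aromatic carbon. The 1H-indol-6-yl group replaces 3-methylphenyl on the same aromatic carbon, next to the ring nitrogen and next to the ring oxygen.

The measured steps that bear on it all swap the aryl group at this carbon. These are an at least 1.3-fold lower number from compound 1 to compound 2 (0.13 log units; that floor lies within the scatter), an at least 1.3-fold higher number from compound 2 to compound 3 (0.13 log units; that floor lies within the scatter) and a step that the two limits leave unreadable from compound 1 to compound 3. The first two are floors within the scatter and the third cannot be read, so none gives a real size, and none of them involves a fused aryl group. The expectation therefore rests on compound 2 at 18500 nM. Compound 4 is expected to stay in the same weak region, possibly at the limit again. The expected step is an at least 1.7-fold lower number from compound 3 to compound 4 (0.25 log units; that floor lies within the scatter), small and towards a lower number. For compound 4 the estimated value is 14000 nM, with an expected range of 3500 nM to 30000 nM.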

Compound 4, half-maximal inhibitory concentration: 300 nM
The estimate for compound 4 lay 47-fold (1.67 log units) above the measured number; the whole stated range lies above it.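

At this aromatic carbon, next to the ring nitrogen and next to the ring oxygen, the choice of aryl group can move the reading in this assay by far more than the scatter: 1H-indol-6-yl gives an at least 83-fold lower number from compound 3 to compound 4 (1.92 log units; beyond the scatter) and an at least 83-fold lower number from compound 1 to compound 4 (1.92 log units; beyond the scatter). The step with a measured number at both ends is a 62-fold lower number from compound 2 to compound 4 (1.79 log units; beyond the scatter), so this position, which had shown no readable change among the 4-fluorophenyl, 3-chlorophenyl and 3-methylphenyl groups, does respond to the aryl group placed on it. The steps from compound 1 and compound 3 are only floors, and their true size may be larger, because those two compounds sit at a limit of the assay: the limit of > 25000 nM in this assay, at which 2 of the 4 values shown sit.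

The compounds shown leave open whether the step follows the fused ring or the hydrogen-bond donor that 1H-indol-6-yl brings in; a naphthalen-2-yl or a 1-methyl-1H-indol-6-yl group at this carbon would bear on that. Also open, on these data alone, is whether attachment through another indole carbon, as in 1H-indol-5-yl, would give a similar reading.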